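2,6-Dichlorophenyl in place of 2,6-dimethylphenyl

The source may report more compounds than this note shows. Statements on the series, on what has been measured and on what is new or still open speak of the compounds shown alone.

In a functional assay on SK-MEL-147 cells (Homo sapiens) for cytotoxicity, read by MTT assay, with a stated time of 24 h (on this read-out higher numbers stand for an effect only at larger amounts of compound and lower numbers for an effect already at smaller amounts), compound 1 (`CCOC(=O)c1cc([Se]c2ccccc2)c2cc(Cl)ccc2n1`) gives 47100 nM and compound 2 (`COc1ccc2nc(-c3c(C)cccc3C)cc([Se]c3ccccc3)c2c1`) gives 37300 nM, two values within the scatter of each other. Compound 3 (`CCOC(=O)c1cc([Te]c2ccccc2)c2cc(OC)ccc2n1`) gives 128000 nM, a higher number than compound 2 by more than the scatter. Compound 2 therefore sits with compound 1 at the low end of the three numbers.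

Compound 4 (`COc1ccc2nc(-c3c(Cl)cccc3Cl)cc([Se]c3ccccc3)c2c1`) differs from compound 2 in one place: 2,6-dichlorophenyl in place of 2,6-dimethylphenyl on an aromatic carbon. For the measured compounds named here, no two measured compounds differ in only one place, so the data contain no direct measure of this or any other single change. In this assay, the expectation is therefore anchored on compound 2 at 37300 nM, with no step beyond the scatter and no firm direction. The estimated step, a 1.1-fold lower number from compound 2 to compound 4 (0.05 log units; within the scatter), is accordingly small. For compound 4 the expected value is 33000 nM, with an estimated range from 14000 nM to 75000 nM.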

Compound 4, half-maximal effective concentration: > 150000 nM
Compound 4 gave a limit, no number; the forecaster's own chance of this, stated with the estimate: 5%; at least 4.5-fold (0.65 log units) between middle value and limit.
By their numbers in this assay, from the lowest: compounds 2 and 1 (each within the scatter of the next); then compound 3. At a limit, above all of these: compound 4.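

In this assay, for the compounds shown here, the first single change that can be read is 2,6-dichlorophenyl in place of 2,6-dimethylphenyl on the aromatic carbon next to the ring nitrogen, and it gives an at least 4.0-fold higher number from compound 2 to compound 4 (0.60 log units; beyond the scatter). The two groups match in heavy atoms and in hydrogen-bond donors and acceptors, so this position responds to a change that leaves those counts untouched. Compound 4 stands at a limit of the assay, > 150000 nM, not at a number, so the step marks only a minimum size: the limit of > 150000 nM in this assay, at which 1 of the 4 values shown sits.

Going by these compounds, how far compound 4 lies past its limit stays unknown, and a single pair cannot separate the chlorine atoms from any other account of the step. On these data alone, whether an unsubstituted phenyl or an aminophenyl at this position would sit with compound 2 or with compound 4 remains open.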